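Removing one cyanophenyl arm from a triazole aromatase inhibitor

The source may hold more compounds than are shown below. What is called first, only, known or untested is meant among the compounds shown, and "the series" means these compounds.

Three compounds share a core in which two 4-cyanophenyl groups sit on one carbon attached to a triazole that carries an aryl ether. In an assay on isolated protein for inhibition of Aromatase (Homo sapiens), read by fluorescence and colorimetric assay, with a stated time of 30 min (a lower number here means a stronger inhibitor, a higher number a weaker inhibitor), compound 1 `N#Cc1ccc(C(c2ccc(C#N)cc2)n2cc(COc3ccc([N+](=O)[O-])cc3)nn2)cc1` gives 7730 nM, compound 2 `Cc1ccc(OCc2cn(C(c3ccc(C#N)cc3)c3ccc(C#N)cc3)nn2)cc1` gives 11000 nM, and compound 3 `COc1ccc(OCc2cn(C(c3ccc(C#N)cc3)c3ccc(C#N)cc3)nn2)cc1` gives 12200 nM. Compound 2 stands second highest of the three, with a 1.1-fold higher number from compound 2 to compound 3 (0.04 log units; within the scatter) and a 1.4-fold higher number from compound 1 to compound 2 (0.15 log units; within the scatter), so all three sit together in this assay. Compound 4 `Cc1ccc(OCc2cn(Cc3ccc(C#N)cc3)nn2)cc1` differs from compound 2 by hydrogen in place of 4-cyanophenyl on a saturated chain carbon bound to an aromatic carbon and an aromatic nitrogen. The measured steps, including a 1.6-fold higher number from compound 1 to compound 3 (0.20 log units; within the scatter), all change the aryl ether end and none touches the cyanophenyl-bearing carbon, so they give no direct guide to this change; they show only that the aryl ether end tolerates small swaps. For compound 4 a weaker inhibition is expected, estimated at 25000 nM in this assay, spanning 8000 nM to 80000 nM, which corresponds to an expected 2.3-fold higher number from compound 2 to compound 4 (0.36 log units; beyond the scatter).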

Compound 4, half-maximal inhibitory concentration: 4170 nM
Compound 4: the middle estimate sits 6.0-fold (0.78 log units) above what was measured; measured number outside the range, below it.
By their numbers in this assay, from the lowest: compounds 4, 1, 2 and 3 (each within the scatter of the next, the first and the last beyond it).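

Within the data shown here, every earlier step changed the aryl ether end, so compound 4 gives the first reading at the saturated chain carbon bound to an aromatic carbon and an aromatic nitrogen. In this assay, hydrogen in place of 4-cyanophenyl there gives a 2.6-fold lower number from compound 2 to compound 4 (0.42 log units; beyond the scatter), a modest step, so for this pair the second 4-cyanophenyl is not needed for inhibition and its loss leaves the stronger inhibitor. Nothing given here explains the direction of this step.

On these data alone, the same change appears only with the methyl-bearing aryl ether, so it remains open whether it would hold with the nitro group of compound 1 or the methoxy group of compound 3. As far as these compounds go, it also remains open how a methyl group, a longer chain or an amine would fare on that carbon in place of hydrogen.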